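Swapping a Halogenated Phenyl for Pyrimidinyl on a Ring Nitrogen

The compounds below may be only part of what the source reports. "The series", "measured", "known", "first", "only" and "open" are said of these compounds alone.

Compound 1 `CO[C@@H]1CC=C2NN(c3cc(F)cc(Cl)c3)C(=O)C[C@]2(c2ccccc2)O1` was tested in a functional assay on A549 cells (Homo sapiens) for inhibition, read by sulforhodamine B assay, with a stated time of 48 h (a lower number here means a stronger inhibitor, a higher number a weaker inhibitor), where compound 1 gives 14100 nM. Among the three measured compounds it has the second highest number. Compound 2 `CO[C@@H]1CC=C2NN(c3cccnc3)C(=O)C[C@]2(C)O1` gives 14400 nM in this assay, which lies within the scatter of compound 1. Compound 3 `COc1cc(OC)cc(N2NC3=CC[C@@H](OC)O[C@@]3(c3ccncc3)CC2=O)c1` gives 6220 nM in this assay, a lower number than compound 1 and beyond the scatter. Compound 4 `CO[C@@H]1CC=C2NN(c3cncnc3)C(=O)C[C@]2(c2ccccc2)O1` has not yet been measured; it differs from compound 1 by pyrimidin-5-yl in place of 3-chloro-5-fluorophenyl on an amide-type nitrogen in a ring. Within the data shown here, no measured pair shows this change on its own, so the size of the step is uncertain. In this assay only a small step, a 1.4-fold higher number from compound 1 to compound 4 (0.15 log units; within the scatter), is expected, most likely within the scatter. Compound 4 is estimated at 20000 nM, with a range from 7000 nM to 60000 nM.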

Compound 4, half-maximal inhibitory concentration: 5200 nM
For compound 4 the middle estimate is 3.8-fold (0.59 log units) above the measured one; the whole stated range lies above it.
By their numbers in this assay, from the lowest: compounds 4 and 3 (each within the scatter of the next); then compounds 1 and 2 (each within the scatter of the next).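

At the amide-type nitrogen in a ring, pyrimidin-5-yl in place of 3-chloro-5-fluorophenyl gives a 2.7-fold lower number from compound 1 to compound 4 (0.43 log units; beyond the scatter) in this assay. Among these compounds, this is the first single-place change that can be read at this position, and it shows that the two halogens and the all-carbon ring are not needed for activity in these cells. Nothing available explains this gain.

On these data alone, whether it comes from adding the ring nitrogens or from losing the halogens remains open. Also open, as far as these compounds go, is how an amine or a carboxylic acid on this ring would read.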